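The source may report more compounds than this note shows. Statements on the series, on what has been measured and on what is new or still open speak of the compounds shown alone.

Measured so far in a functional assay on HT-29 cells (Homo sapiens) for inhibition, read by luminescence and CellTiter-Glo, with a stated time of 24 h; a lower number here means that less compound is needed, a higher number that more compound is needed for the effect:
Compound 1 `CCCCn1nc(C(=O)N[C@H]2COc3ccccc3N(C)C2=S)nc1Cc1ccccc1` gives 510 nM
Compound 2 `CCCCCn1nc(C(=O)N[C@H]2COc3ccccc3N(C)C2=S)nc1Cc1ccccc1` gives 805 nM
Compound 3 `CN1C(=S)[C@@H](NC(=O)c2nc(Cc3ccccc3)n(CCCC#N)n2)COc2ccccc21` gives 2400 nM

Compound 3, at 2400 nM on this scale, has the highest number of the three and so needs the most compound for the effect. The next compound, compound 4 `CN1C(=S)[C@@H](NC(=O)c2nc(Cc3ccccc3)n(C3CCCCC3)n2)COc2ccccc21`, has not yet been measured. It carries cyclohexyl in place of 3-cyanopropyl on an aromatic nitrogen. Going by the values given here, three measured steps bear on this change. Extending the all-carbon chain changed little, with a 1.6-fold higher number from compound 1 to compound 2 (0.20 log units; within the scatter) as the result. Putting cyano in place of the chain end gave larger steps, namely a 4.7-fold higher number from compound 1 to compound 3 (0.67 log units; beyond the scatter) and also a 3.0-fold higher number from compound 2 to compound 3 (0.47 log units; beyond the scatter) in the same direction. The cyano group leaves in the new change, so a modest step to a lower number is expected in this assay as a partial reverse of a 3.0-fold higher number from compound 2 to compound 3 (0.47 log units; beyond the scatter) and no more. Among the compounds with values here, no measured compound has a ring on this nitrogen, so the expectation stays loose. The expected step is a 2.4-fold lower number from compound 3 to compound 4 (0.38 log units; beyond the scatter) in this estimate. For compound 4 the estimated value is 1000 nM with an expected range from 300 nM to 3500 nM as its limits of expectation.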

Compound 4, half-maximal effective concentration: 4000 nM
For compound 4 the middle estimate is 4.0-fold (0.60 log units) below the measured one; the whole stated range lies below it.
By their numbers in this assay, from the lowest: compounds 1 and 2 (each within the scatter of the next); then compounds 3 and 4 (each within the scatter of the next).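

In this assay the exchange of 3-cyanopropyl for cyclohexyl on this aromatic nitrogen comes to a 1.7-fold higher number from compound 3 to compound 4 (0.22 log units; within the scatter) as its step, so losing the nitrile here did not return the number towards those of the all-carbon chains. Going by these compounds alone, measured against those chains, cyclohexyl gives a 5.0-fold higher number from compound 2 to compound 4 (0.70 log units; beyond the scatter) from pentyl and a 7.8-fold higher number from compound 1 to compound 4 (0.89 log units; beyond the scatter) from butyl as its steps, which shows that a chain ending in a nitrile is not the only group at this position that goes with a higher number than butyl and pentyl. Nothing available here accounts for these steps.

The compounds shown leave open how a cyclopentyl or phenyl ring, or an open branched group such as isopropyl, would read on this nitrogen, so the ring cannot yet be separated from the branching it brings. They also leave open whether a chain shorter than butyl, or a chain ending in an amine or a carboxylic acid in place of the nitrile, would stand with compound 1 and compound 2 or with compound 3 and compound 4.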